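Morpholin-4-yl replacing 4-(piperidin-1-yl)piperidin-1-yl on the amide

The compounds below may be only part of what the source reports. "The series", "measured", "known", "first", "only" and "open" are said of these compounds alone.

Among the measured compounds shown here, compound 1 `O=C(c1ccc(-c2ccc3ncc(-c4ccc5cnccc5c4)n3c2)cc1)N1CCC(N2CCCCC2)CC1` stands highest of the two numbers so far in an assay on Sf21 cells for inhibition of MAP kinase-interacting serine/threonine-protein kinase 1 (Homo sapiens), read by luminescence and ADP-Glo, with stated times of 10 min and 40 min, tested at 500 nM (a higher number here means more inhibition at the concentration tested (going by the name of the read-out), a lower number less inhibition), where compound 1 gives 92.9%. Compound 2 `O=C(c1ccc(-c2ccc3ncc(-c4cnc5ccccc5c4)n3c2)cc1)N1CCC(N2CCCCC2)CC1` gives 71% in this assay; the step of a number 21.9 percentage points lower from compound 1 to compound 2 (beyond the scatter) concerns the aromatic group, not the amide. Compound 3 `O=C(c1ccc(-c2ccc3ncc(-c4ccc5cnccc5c4)n3c2)cc1)N1CCOCC1` differs from compound 1 by morpholin-4-yl in place of 4-(piperidin-1-yl)piperidin-1-yl on a carbonyl carbon. For the measured compounds named here, no measured step touches the amide, so nothing bears on this change directly; it removes one of the two rings counted, so a downward step of a number 22.9 percentage points lower from compound 1 to compound 3 (beyond the scatter) is expected rather than none. Compound 3 is estimated at 70%, between 40% and 92%.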

Compound 3, a percentage reported as inhibition, at one concentration (the size of the read-out at that concentration, not a potency): 93.7%
For compound 3 the middle estimate is 23.7 percentage points below the measured one; measured number outside the range, above it.
By their numbers in this assay, from the lowest: compound 2; then compounds 1 and 3 (each within the scatter of the next).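

At the carbonyl carbon, morpholin-4-yl in place of 4-(piperidin-1-yl)piperidin-1-yl gives a number 0.8 percentage points higher from compound 1 to compound 3 (within the scatter) in this assay, so this assay does not separate the two amides. The second non-aromatic ring and the extra heavy atoms of the larger group are thus not needed for this read-out at the concentration tested. No measured evidence bears on why the two groups read alike. Open, on these data alone, is whether piperazin-1-yl or a dimethylamino group at the carbonyl carbon holds the same level, and whether morpholin-4-yl does so with the quinolin-3-yl of compound 2.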